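Swapping chloro for phenoxy on the pendant aromatic ring

The source may report more compounds than this note shows. Statements on the series, on what has been measured and on what is new or still open speak of the compounds shown alone.

Of the compounds shown here, three sharing one core have been tested in a functional assay on SK-MEL-5 cells (Homo sapiens) for cytotoxicity, read by sulforhodamine B assay, with a stated time of 48 h; a higher number here means a weaker inhibitor of growth, a lower number a stronger inhibitor of growth. Compound 1 `CC1=C(C(=O)Nc2ccc(Cl)c(Cl)c2)C(c2cccc(O)c2)NC(=S)N1` gives 10000 nM. Compound 2 `CC1=C(C(=O)Nc2ccc(F)c(Cl)c2)C(c2cccc(Cl)c2)NC(=S)N1` gives 8320 nM. Compound 3 `CC1=C(C(=O)Nc2ccc(F)c(Cl)c2)C(c2ccccc2Cl)NC(=S)N1` gives 12300 nM. These three numbers sit within the usual scatter of one another, so compound 2 cannot be set apart from compound 1 or compound 3 on these data; all three are weak inhibitors of growth in this assay.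

Within the data shown here, only one single-point step is available. Moving the chlorine on the saturated ring carbon's aromatic substituent, from compound 2 to compound 3, gave a 1.5-fold higher number from compound 2 to compound 3 (0.17 log units; within the scatter).

Compound 4 `CC1=C(C(=O)Nc2ccc(F)c(Cl)c2)C(c2cccc(Oc3ccccc3)c2)NC(=S)N1` differs from compound 2 by phenoxy in place of chloro on an aromatic carbon. Among the measured compounds shown here, no measured step replaces a chloro with a phenoxy anywhere in this set, so nothing here speaks directly to the change. For the measured compounds named here, the one step that does touch the same aromatic ring, from compound 2 to compound 3, stayed within the scatter, and the whole set spans a narrow band of weak values.

Compound 4 is therefore expected to stay close to compound 2, with a step of about a 1.1-fold higher number from compound 2 to compound 4 (0.03 log units; within the scatter) in this assay. The estimate for compound 4 is 9000 nM, with a range from 3000 nM to 30000 nM.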

Compound 4, concentration for 50% growth inhibition: 8910 nM
Compound 4: the middle estimate sits 1.0-fold (0.00 log units) above what was measured; measured number inside the range.
By their numbers in this assay, from the lowest: compounds 2, 4, 1 and 3 (each within the scatter of the next).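

The aromatic carbon that carries chloro in compound 2 also accepts a far larger group: phenoxy, with 7 heavy atoms and its own six-membered aromatic ring, replaces chloro, with 1 heavy atom, and gives a 1.1-fold higher number from compound 2 to compound 4 (0.03 log units; within the scatter) in this assay. Among these compounds, the earlier step only moved a chlorine around the ring, so this is the first sign in the set that the group itself can be exchanged for one much larger while the two numbers remain indistinguishable, and both compounds remain weak inhibitors of growth. Nothing measured alongside these numbers explains why the two groups read alike.

Still open, from the compounds shown here alone, is whether this carbon would tolerate a group of a different kind, such as an amine or a carboxylic acid, as readily as it tolerates phenoxy. Also open, going by these compounds, is whether phenoxy would read the same when paired with the amide ring of compound 1, and whether any change at this position can move a compound out of this narrow band of weak values.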